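Shortening the long chain: from compound 2 to compound 3

This account rests on a few compounds, and the source may have more. Where it says the series, first, only, none or still open, it means among the compounds named here.

Compound 1 (`CCn1c(-c2ccc(C)cc2C)cs/c1=N\C(=O)c1ccccc1`) gives 1950 nM
Compound 2 (`CCCCCCCCCCCCn1c(-c2ccc(C)cc2C)cs/c1=N\C(=O)c1ccccc1`) gives 24 nM

Of the two compounds measured in a functional assay on MDA-MB-231 cells (Homo sapiens), read by microscopy and transwell migration, with a stated time of 24 h (on this read-out lower numbers stand for stronger inhibition and higher numbers for weaker inhibition), compound 2 has the lower number and so inhibits more strongly. Compound 3 (`C#CCn1c(-c2ccc(C)cc2C)cs/c1=N\C(=O)c1ccccc1`) makes one change from it (ethynyl in place of undecyl on a saturated chain carbon bound to an aromatic nitrogen), ethynyl in place of undecyl on a saturated chain carbon bound to an aromatic nitrogen. Going by the values given here, the one measured step bearing on this (an 81-fold lower number from compound 1 to compound 2 (1.91 log units; beyond the scatter)) is large and came with decyl in place of hydrogen on that chain. Compound 3 has no such long chain, so a similarly large step to a higher number is expected (a 63-fold higher number from compound 2 to compound 3 (1.80 log units; beyond the scatter)). Compound 3 is expected at 1500 nM, within an estimated range of 350 nM to 6000 nM.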

Compound 3, half-maximal inhibitory concentration: 3890 nM
For compound 3 the middle estimate is 2.6-fold (0.41 log units) below the measured one, within the range that was stated.
By their numbers in this assay, from the lowest: compound 2; then compounds 1 and 3 (each within the scatter of the next).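

Swapping undecyl for ethynyl on this carbon removes almost all of the strength of compound 2 (a 160-fold higher number from compound 2 to compound 3 (2.21 log units; beyond the scatter)). The two short groups, however, cannot be told apart (a 2.0-fold higher number from compound 1 to compound 3 (0.30 log units; within the scatter)), so among these compounds only the long chain stands out, and the triple bond adds nothing that can be seen. No evidence here explains the size of this loss.

Still open, on these data alone, is how strength changes between the short chains and the long one, which a hexyl chain could help to show, and whether an amine at the end of the long chain would keep it.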